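Amidoxime series: piperidine amide replacing trifluoromethyl

The source may hold more compounds than are shown below. What is called first, only, known or untested is meant among the compounds shown, and "the series" means these compounds.

In an assay on tissue (HeLa cells) for inhibition of Indoleamine 2,3-dioxygenase 1 (Homo sapiens), read by spectrophotometry (on this read-out lower numbers stand for stronger inhibition and higher numbers for weaker inhibition), compound 1 `O/N=C(/Nc1cccc(F)c1)c1ccc2occc2c1` gives 20000 nM, compound 2 `O/N=C(/Nc1cccc(C(F)(F)F)c1)c1ccc2occc2c1` gives 1900 nM, and compound 3 `O/N=C(/Nc1ccc(F)c(C(F)(F)F)c1)c1ccc2occc2c1` gives 2200 nM. Compound 2 holds the lowest of the three numbers; compound 3 lies within the scatter of it, and compound 1 sits beyond the scatter above it. The step of an 11-fold lower number from compound 1 to compound 2 (1.02 log units; beyond the scatter) is the only large one seen, and it sits on the same aromatic carbon that is varied next. The step of a 1.2-fold higher number from compound 2 to compound 3 (0.06 log units; within the scatter) is within the scatter.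

Compound 4 `CC1CCN(C(=O)c2cccc(N/C(=N/O)c3ccc4occc4c3)c2)CC1` differs from compound 2 by (4-methylpiperidin-1-yl)carbonyl in place of trifluoromethyl on an aromatic carbon. Among the measured compounds shown here, no measured step replaces the trifluoromethyl with a group of this kind, so the prior is weak. The step from compound 1 to compound 2 shows the position accepts a larger group with a lower number, while nothing tells how the amide will read. For compound 4 in this assay the expected step is a 1.3-fold higher number from compound 2 to compound 4 (0.12 log units; within the scatter), with wide bounds. Compound 4 is therefore estimated at 2500 nM, within a range from 400 nM to 15000 nM.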

Compound 4, half-maximal inhibitory concentration: > 30000 nM
Compound 4 ended at the assay's limit (the forecaster's own chance of this, stated with the estimate: 5%); at least 12-fold (1.07 log units) between middle value and limit.
By their numbers in this assay, from the lowest: compounds 2 and 3 (each within the scatter of the next); then compound 1. At a limit, above all of these: compound 4.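

In this assay compound 4 reads > 30000 nM, which is a limit of the assay and not a number: the limit of > 30000 nM in this assay, at which 1 of the 4 values shown sits. Up to now, the larger group at this aromatic carbon had given the lower number, but (4-methylpiperidin-1-yl)carbonyl in place of trifluoromethyl gives an at least 15-fold higher number from compound 2 to compound 4 (1.19 log units; beyond the scatter), so size alone does not carry the earlier trend. Against fluoro the change reads an at least 1.5-fold higher number from compound 1 to compound 4 (0.17 log units; that floor lies within the scatter), so compound 4 cannot be separated from compound 1 in this assay, and the amide shows no advantage over the smaller fluoro.

The compounds shown leave open whether the carbonyl, the piperidine ring or its methyl accounts for the step. A piperidine amide without the methyl, a dimethyl amide, a primary carboxamide or a carboxylic acid at this aromatic carbon would separate these parts.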